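The source may hold more compounds than are shown below. What is called first, only, known or untested is meant among the compounds shown, and "the series" means these compounds.

Of the compounds shown here, two have been tested in an in vitro functional assay on RBL cells for antagonist activity at C-C chemokine receptor type 8 (Homo sapiens), read by FLIPR and calcium flux; on this read-out higher numbers stand for weaker inhibition and lower numbers for stronger inhibition. Compound 1 `COc1ccc2nccc(C3CN(CC4CCN(Cc5cc6ccccc6[nH]5)CC4)C(=O)O3)c2c1` gives only a limit in this assay, < 50200 nM. For the measured compounds named here, compound 2 `COc1ccc2nccc(C3CN(C4CCN(Cc5cc6ccccc6o5)CC4)C(=O)O3)c2c1` gives 1260 nM in this assay, which is the only plain number in the set. The other entry, that of compound 1, is a limit, (the limit of < 50200 nM in this assay, at which 1 of the 2 values shown sits). Going by the values given here, compound 2 therefore cannot be ranked against anything, and no step between measured compounds can be stated.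

Compound 3 `COc1ccc(CN2CCC(N3CC(c4ccnc5ccc(OC)cc45)OC3=O)CC2)cc1` has not yet been measured in this assay. It differs from compound 2 in one place: 4-methoxyphenyl in place of 1-benzofuran-2-yl on a saturated chain carbon bound to an amine nitrogen in a ring. The 1-benzofuran-2-yl group is swapped for 4-methoxyphenyl on a saturated chain carbon bound to an amine nitrogen in a ring.

Among the compounds with values here, with no measured step to lean on, the expectation is a modest loss of inhibition, a step from compound 2 to compound 3 of a 2.5-fold higher number from compound 2 to compound 3 (0.40 log units; beyond the scatter), beyond the usual scatter but not by much. Compound 3 is therefore estimated at 3200 nM in this assay, with a range from 1000 nM to 10000 nM.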

Compound 3, half-maximal inhibitory concentration: 1260 nM
For compound 3 the middle estimate is 2.5-fold (0.40 log units) above the measured one; measured number inside the range.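

In this assay, for the compounds shown here, the swap of 1-benzofuran-2-yl for 4-methoxyphenyl gives no change at the digits printed from compound 2 to compound 3 (within the scatter), the only step that can be read at this place, on a saturated chain carbon bound to an amine nitrogen in a ring. For this pair, the five-membered aromatic ring with its hetero atom can be replaced by a single six-membered carbon ring carrying a methoxy group with no change beyond the scatter. Nothing shown here explains why these two groups read alike.

Going by these compounds, one pair cannot show how much else this place tolerates, so it remains open whether the same read-out would hold with plain phenyl or with a carboxylic acid or an amine in place of the methoxy group. On these data alone, it also remains open whether a longer chain between the ring and the amine nitrogen would alter the read-out.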